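Moving the Trifluoromethyl Group Around the Benzoyl Ring

The compounds below may be only part of what the source reports. "The series", "measured", "known", "first", "only" and "open" are said of these compounds alone.

Compound 1 `O=C(Nc1nc(-c2ccccc2)nc2c1nnn2Cc1ccccc1)C1CCCC1` carries a cyclopentyl group on a carbonyl carbon; in an assay (strain Wistar) for displacement of a labelled ligand from adenosine receptor A1 (Rattus norvegicus), read by scintillation counting (on this read-out higher numbers stand for weaker inhibition and lower numbers for stronger inhibition), compound 1 gives 2.5 nM. Compound 2 `O=C(Nc1nc(-c2ccccc2)nc2c1nnn2Cc1ccccc1)c1ccc(C(F)(F)F)cc1` carries a 4-(trifluoromethyl)phenyl group in that place instead, and in this assay compound 2 gives 123 nM. That replacement produced a 49-fold higher number from compound 1 to compound 2 (1.69 log units; beyond the scatter). Among the compounds with values here, compound 2 therefore stands at the highest of the two numbers measured so far, its nearest neighbour being compound 1 at the lower number. Compound 3 `O=C(Nc1nc(-c2ccccc2)nc2c1nnn2Cc1ccccc1)c1cccc(C(F)(F)F)c1` is the next step: 3-(trifluoromethyl)phenyl in place of 4-(trifluoromethyl)phenyl on a carbonyl carbon. Within the data shown here, no measured step compares two trifluoromethylphenyl groups that differ only in where the trifluoromethyl sits, and the single measured step, from a cyclopentyl to an aryl group, bears on this change only indirectly. The expected outcome is a 1.2-fold lower number from compound 2 to compound 3 (0.09 log units; within the scatter), a step not beyond the scatter. Compound 3 is therefore estimated at 100 nM, within a range from 30 nM to 400 nM.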

Compound 3, inhibition constant: 163 nM
Compound 3: the middle estimate sits 1.6-fold (0.21 log units) below what was measured; the range from low to high includes it.
By their numbers in this assay, from the lowest: compound 1; then compounds 2 and 3 (each within the scatter of the next).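

Moving the trifluoromethyl group, with 3-(trifluoromethyl)phenyl taking the place of 4-(trifluoromethyl)phenyl on the carbonyl carbon, gives a 1.3-fold higher number from compound 2 to compound 3 (0.12 log units; within the scatter) in this assay and so does not separate these two compounds. Compound 3 also stays far from the cyclopentyl amide, with a 65-fold higher number from compound 1 to compound 3 (1.81 log units; beyond the scatter) on the same read-out, which shows that the large gap first seen with compound 2 is not confined to the 4-(trifluoromethyl)phenyl group. No supporting evidence is available to explain either step.

The compounds shown leave open where a plain phenyl or a cyclohexyl group on that carbonyl carbon would fall, and so whether the higher numbers go with the aromatic ring or with the trifluoromethyl group. They also leave open whether a methoxy group or a chlorine atom on the ring would behave as the trifluoromethyl group does.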